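This account rests on a few compounds, and the source may have more. Where it says the series, first, only, none or still open, it means among the compounds named here.

Compound 1 (`CC1(C)CCc2c(C3CCc4ccc(O)cc4O3)ccc(O)c2O1`) stands at 51000 nM in a functional assay on Hep 3B2 cells (Homo sapiens) for cytotoxicity, read by MTT assay (on this read-out lower numbers stand for stronger inhibition and higher numbers for weaker inhibition), and lies within the scatter of compound 2 (`CC1(C)C=Cc2c(C3CCc4ccc(O)cc4O3)ccc(O)c2O1`) at 57400 nM on the same read-out. Compound 3 (`CC1(C)CCc2c([C@H]3CCc4ccc(O)cc4O3)ccc(O)c2O1`) has the same atoms and bonds as compound 1 (the two compounds have the same atoms and bonds; at least one stereo element is drawn with a configuration in one of them and without one in the other: 1 of 1 stereo elements differ; a stereocentre at a saturated ring carbon is drawn without a configuration in compound 1 and R in compound 3) and a stereocentre at a saturated ring carbon, drawn without a configuration in compound 1, is R in compound 3. Within the data shown here, no measured pair shows such a change, so no step beyond the scatter is expected in this assay in either direction. The estimated 1.1-fold lower number from compound 1 to compound 3 (0.03 log units; within the scatter) stays inside the scatter. Compound 3 is expected at 48000 nM with an estimated range of 25000 nM to 95000 nM on this read-out.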

Compound 3, half-maximal inhibitory concentration: 41700 nM
Beside the measured number, compound 3's estimate is 1.2-fold (0.06 log units) above it, and the stated range covers the measured number.
By their numbers in this assay, from the lowest: compounds 3, 1 and 2 (each within the scatter of the next).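

In this assay the only stereo change shown, at the saturated ring carbon, reads as a 1.2-fold lower number from compound 1 to compound 3 (0.09 log units; within the scatter) and so gives no step at this position when the stereocentre is drawn as R. The reading carries one limit, since it compares a defined drawing with an undefined one: the fact that one of compounds 1 and 3 is drawn with a defined configuration and the other without, at the place where they differ

Open, going by these compounds, is whether the S configuration at this carbon would also stay inside the scatter. Also open, on these data alone, is whether a methoxy or an amine in place of a hydroxyl on the shared core would give a step beyond it.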